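The compounds below may be only part of what the source reports. "The series", "measured", "known", "first", "only" and "open" are said of these compounds alone.

Working notes on the series: in a functional assay on Caco-2 cells (Homo sapiens) for inhibition, read by MTT assay, with a stated time of 48 h, tested at 10 uM (a higher number here means more inhibition of growth at the concentration tested, a lower number less inhibition of growth), compound 1 (`CN1CC[C@H](c2c(O)cc(O)c3c(=O)cc(/C=C/c4ccccc4)oc23)[C@H](O)C1`) gives 72% and compound 2 (`CN1CC[C@H](c2c(O)cc(O)c3c(=O)cc(/C=C/c4cccc(F)c4)oc23)[C@H](O)C1`) gives 61% as the lower of the two numbers. Compound 3 (`CN1CC[C@H](c2c(O)cc(O)c3c(=O)cc(/C=C/c4ccccc4Cl)oc23)[C@H](O)C1`) differs from compound 2 by 2-chlorophenyl in place of 3-fluorophenyl on a double-bonded chain carbon bound to a double-bonded chain carbon on a double-bonded chain carbon bound to a double-bonded chain carbon. Among the compounds with values here, only one measured step bears on this change, the modest a number 11 percentage points lower from compound 1 to compound 2 (beyond the scatter) for fluoro in place of hydrogen on an aromatic carbon, and no chloro compound has been measured. With no direction supported, no step beyond the scatter is expected. The estimated step is a number 1 percentage points higher from compound 2 to compound 3 (within the scatter) in this read-out. For compound 3 the expected value is 62% with an estimated range from 46% to 78% for now.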

Compound 3, percent growth inhibition at one concentration: 65%
For compound 3 the middle estimate is 3 percentage points below the measured one; the measured number falls inside the stated range.
By their numbers in this assay, from the lowest: compounds 2, 3 and 1 (each within the scatter of the next, the first and the last beyond it).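

In this assay the change to 2-chlorophenyl gives a number 4 percentage points higher from compound 2 to compound 3 (within the scatter) and so does not separate it from 3-fluorophenyl at this position on a double-bonded chain carbon bound to a double-bonded chain carbon. The chloro group gives a number 7 percentage points lower from compound 1 to compound 3 (within the scatter) and, unlike the fluoro step, stays within the scatter. Nothing available accounts for these numbers. Open, from the compounds shown here alone, is whether an amine or a carboxylic acid in place of the chloro, or a longer chain in place of 2-(2-chlorophenyl)ethenyl, would give a step beyond the scatter.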